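This account rests on a few compounds, and the source may have more. Where it says the series, first, only, none or still open, it means among the compounds named here.

Compound 1 `COC(=O)[C@H](CCSC)NC(=O)c1ccc(NCc2cncn2Cc2ccc(C)cc2)cc1-c1ccccc1`: > 10 uM
Compound 2 `CSCC[C@H](NC(=O)c1ccc(NCc2cncn2Cc2ccc(C)cc2)cc1-c1ccccc1)C(=O)O`: > 10 uM
Compound 3 `N#Cc1ccc(Cn2cncc2CNc2ccc(C(=O)NCC3CCCCC3)c(-c3ccccc3)c2)cc1`: > 10 uM

In a functional assay on NIH3T3 cells (Mus musculus) (a lower number here means that less compound is needed, a higher number that more compound is needed for the effect), compound 2 reaches only a limit, not a number. Among the compounds with values here, the same holds for compound 1 and compound 3, so that (the limit of > 10 uM in this assay, at which 3 of the 3 values shown sit); the step from compound 1 to compound 2 a step that the two limits leave unreadable from compound 1 to compound 2 is therefore unreadable, and no measured step gives a size to lean on. Compound 4 `CSCC[C@H](NC(=O)c1ccc(NCc2cncn2Cc2ccc(Cl)cc2)cc1-c1ccccc1)C(=O)O` carries chloro in place of methyl on an aromatic carbon relative to compound 2. With every measured value sitting at the limit, the expectation for compound 4 is that it too stays there, with the step from compound 2 to compound 4 estimated as a step that the limit leaves unreadable from compound 2 to compound 4. Compound 4 is estimated at 20 uM in this assay, within a range from 5 uM to 100 uM.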

Compound 4, concentration for half-maximal effect: > 10 uM
Compound 4: only a limit was reported; the forecaster's own chance of this, stated with the estimate: 80%; the middle value lies beyond the limit too.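

Compound 2 and compound 4 both sit at a limit, so the step from methyl to chloro between them cannot be read: the limit of > 10 uM in this assay, at which 4 of the 4 values shown sit. The compounds shown leave open how much of any of them is needed for the effect in this assay.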